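This account rests on a few compounds, and the source may have more. Where it says the series, first, only, none or still open, it means among the compounds named here.

Compound 1, `N#CC1=C(N)Oc2c(c3nc4ccccc4nc3c3ccccc23)C12C(=O)N(Cc1cnnn1-c1ccc(F)cc1)c1ccccc12`, gives > 50000 nM in a functional assay on HepG2 cells (Homo sapiens) for antiproliferative activity, read by MTT assay, with a stated time of 48 h; on this read-out higher numbers stand for weaker inhibition and lower numbers for stronger inhibition. Compound 2, `N#CC1=C(N)Oc2c(c3nc4ccccc4nc3c3ccccc23)C12C(=O)N(Cc1cnnn1-c1ccc(Cl)cc1)c1ccccc12`, gives > 50000 nM in this assay. Compound 3, `N#CC1=C(N)Oc2c(N)cc3nc4ccccc4nc3c2C12C(=O)N(Cc1cnnn1-c1ccc(F)cc1)c1ccccc12`, gives > 50000 nM in this assay.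

Each of these three values is a limit of this assay and not a number: all three sit at the limit of > 50000 nM in this assay, at which 3 of the 3 values shown sit. The change chloro in place of fluoro on an aromatic carbon therefore yields a step that the two limits leave unreadable from compound 1 to compound 2, a step whose size cannot be read. How the core of compound 3 differs from the core of compound 1 is not broken down here.

Compound 4, `N#CC1=C(N)Oc2c(N)cc3nc4ccccc4nc3c2C12C(=O)N(Cc1cnnn1-c1ccc(Cl)cc1)c1ccccc12`, has not been measured. It differs from compound 3 by chloro in place of fluoro on an aromatic carbon, the same change as that between compound 1 and compound 2, since both sit para to a large group on a six-membered aromatic ring of carbon only. The step that the limit leaves unreadable from compound 3 to compound 4 is expected to be unreadable as well, because a step that the two limits leave unreadable from compound 1 to compound 2 also stays at the limit of > 50000 nM in this assay, at which 3 of the 3 values shown sit. Compound 4 is thus estimated to give 70000 nM in this assay, most likely as a limit.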

Compound 4, half-maximal inhibitory concentration: > 50000 nM
Compound 4: no number, only a limit; the forecaster's own chance of this, stated with the estimate: 85%; the middle value is on the limit's open side.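

Compound 3 and compound 4 both give only a limit, so no step can be read between them: the limit of > 50000 nM in this assay, at which 4 of the 4 values shown sit. The compounds shown leave open whether chloro and fluoro differ at all in this assay.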